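The compounds below may be only part of what the source reports. "The series", "measured", "known", "first", "only" and "open" are said of these compounds alone.

Measured so far:
compound 1, `CC[C@@H]1C(=O)N(C)c2cnc(Nc3ccc(S(=O)(=O)NCCO)cc3)nc2N1C1CCCC1` — 2100 nM
compound 2, `CCCNS(=O)(=O)c1ccc(Nc2ncc3c(n2)N(c2ccn(C)n2)C(CC)C(=O)N3C)cc1` — 21700 nM

In a functional assay on NCI-H1975 cells (Homo sapiens) for antiproliferative activity, read by CCK-8 assay, with a stated time of 72 h (on this read-out higher numbers stand for weaker inhibition of growth and lower numbers for stronger inhibition of growth), compound 1 gives 2100 nM, the lower of the two numbers recorded; compound 2, with 21700 nM, sits at a gap beyond the scatter, but the two structures differ in several places at once and the two values are all that can be read from the pair.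

Compound 3, `CC[C@@H]1C(=O)N(C)c2cnc(Nc3ccc(S(=O)(=O)NCC(C)C)cc3)nc2N1C1CCCC1`, has not been run in this assay. It departs from compound 1 in one place: isopropyl in place of hydroxymethyl on a saturated chain carbon bound to a sulfonamide nitrogen. Among the measured compounds shown here, no pair of measured compounds isolates this kind of exchange, so its effect is not charted by the series. Compound 3 is expected to lie near compound 1 with a modest step toward weaker inhibition, a 1.7-fold higher number from compound 1 to compound 3 (0.22 log units; within the scatter), the wide range reflecting the missing comparison. The estimated value for compound 3 in this assay is 3500 nM, between 1200 nM and 10000 nM.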

Compound 3, concentration for 50% growth inhibition: 1040 nM
The estimate for compound 3 lay 3.4-fold (0.53 log units) above the measured number, outside the stated range (below it).
By their numbers in this assay, from the lowest: compound 3; then compound 1; then compound 2.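

In this assay, among the compounds shown here, the exchange of 2-hydroxyethyl for isobutyl on the sulfonamide gives a 2.0-fold lower number from compound 1 to compound 3 (0.31 log units; beyond the scatter) and is the first single change read at this position. The hydroxyl of compound 1 is therefore not needed for growth inhibition at this level: compound 3, whose entering group has no hydrogen-bond donor or acceptor, gives a modestly stronger reading. No measurement at hand accounts for the step.

This one pair cannot separate the loss of the hydroxyl from the gain of branched carbon, and a longer straight chain, an amine or a carboxylic acid at the same place would test each. Steps to compound 2, which differs in several places, cannot be read.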